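This account rests on a few compounds, and the source may have more. Where it says the series, first, only, none or still open, it means among the compounds named here.

Of the compounds shown here, three sharing one core have been read in an ADME assay on BJ cells (Homo sapiens) for cytotoxicity, with a stated time of 72 h; on this read-out higher numbers stand for an effect only at larger amounts of compound and lower numbers for an effect already at smaller amounts. Compound 1 `COc1cccc(-c2nc3c(c(C)nn3-c3ccccc3)c(-c3ccccc3O)c2C#N)c1` gives > 23000 nM, which is a limit of the assay and not a number. Compound 2 `Cc1cccc(-c2nc3c(c(C)nn3-c3ccccc3)c(-c3ccccc3O)c2C#N)c1` gives > 20000 nM, again only a limit. Going by the values given here, compound 3 `CCCc1ccc(-c2nc3c(c(C)nn3-c3ccccc3)c(-c3ccccc3O)c2C#N)cc1` gives 22500 nM, the only actual number among the three.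

Compound 4 `Cc1nn(-c2ccccc2)c2nc(-c3ccc(C(F)(F)F)cc3)c(C#N)c(-c3ccccc3O)c12` differs from compound 3 in one place: trifluoromethyl in place of propyl on an aromatic carbon. In words, this is trifluoromethyl in place of propyl on an aromatic carbon, para to a large group. Among the compounds with values here, no measured step makes this exact exchange, but three steps alter the same aromatic ring. They are a step that the two limits leave unreadable from compound 1 to compound 2, an at least 1.0-fold lower number from compound 1 to compound 3 (0.00 log units; that floor lies within the scatter) and a step that the limit leaves unreadable from compound 2 to compound 3. None of them shows a change beyond the scatter, so the expectation rests mainly on compound 3 at 22500 nM. The expected step is a 1.0-fold lower number from compound 3 to compound 4 (0.01 log units; within the scatter), which means no real change is anticipated. The estimated value for compound 4 is 22000 nM, with an expected range of 10000 nM to 45000 nM.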

Compound 4, half-maximal effective concentration: 22900 nM
The estimate for compound 4 lay 1.0-fold (0.02 log units) below the measured number; the measured number falls inside the stated range.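

In this assay, going by these compounds alone, trifluoromethyl in place of propyl, para to a large group, gives a 1.0-fold higher number from compound 3 to compound 4 (0.01 log units; within the scatter), and this is the first pair here in which both ends are actual numbers, so a change on this ring can be sized rather than only bounded. Against a limit of the assay, which is not a number, the data show a number no higher from compound 1 to compound 4 (the limit leaves the size open). The step to compound 4 from compound 2 cannot be read: it starts from a limit of the assay and not a number. Nothing measured here gives a reason for this result.

Both groups compared here have no ring, no hydrogen-bond donors or acceptors and no net charge. Going by these compounds, whether an amine or a carboxylic acid at this same place would also leave the read-out within the scatter remains open.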